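Swapping 4-Fluorophenyl for 3,4-Dichlorophenyl in Compound 2

The source may report more compounds than this note shows. Statements on the series, on what has been measured and on what is new or still open speak of the compounds shown alone.

In a functional assay on THP-1 cells (Homo sapiens) for cytotoxicity, read by MTT assay, with a stated time of 24 h (a higher number here means a weaker inhibitor, a lower number a stronger inhibitor), compound 1 (`CN1C/C(=C\c2ccc(C#N)cc2)C(=O)/C(=C/c2ccccc2F)C1`) gives 810 nM and compound 2 (`CN1C/C(=C\c2ccc(F)cc2)C(=O)/C(=C/c2cccc([N+](=O)[O-])c2)C1`) gives 7160 nM as the higher of the two numbers, a gap beyond the scatter, so compound 2 is the weaker inhibitor here. Compound 3 (`CN1C/C(=C\c2cccc([N+](=O)[O-])c2)C(=O)/C(=C/c2ccc(Cl)c(Cl)c2)C1`) differs from compound 2 by 3,4-dichlorophenyl in place of 4-fluorophenyl on a double-bonded chain carbon bound to a double-bonded ring carbon. For the measured compounds named here, no measured pair shows this change alone, so the expectation is loose: a moderate move (a 2.9-fold lower number from compound 2 to compound 3 (0.46 log units; beyond the scatter)) toward a lower number, beyond the scatter, is expected. Compound 3 is estimated at 2500 nM (range 700 nM to 8000 nM).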

Compound 3, half-maximal inhibitory concentration: 5020 nM
Beside the measured number, compound 3's estimate is 2.0-fold (0.30 log units) below it; measured number inside the range.
By their numbers in this assay, from the lowest: compound 1; then compounds 3 and 2 (each within the scatter of the next).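

In this assay, this swap of one halogen-bearing phenyl group for the other gives a 1.4-fold lower number from compound 2 to compound 3 (0.15 log units; within the scatter). At this position, these two halogen-bearing phenyl groups therefore cannot be told apart in this assay. No measured evidence explains this result.

From the compounds shown here alone, whether a morpholine or a carboxylic acid at this position would shift the number beyond the scatter remains open. So does whether this swap gives the same result when the rest of the molecule differs.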